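The source may report more compounds than this note shows. Statements on the series, on what has been measured and on what is new or still open speak of the compounds shown alone.

Of the compounds shown here, two of a shared core have been measured in an assay on cell membranes from brain for binding affinity to adenosine receptor A1 (Rattus norvegicus), read by radioligand binding; a lower number here means a stronger inhibitor, a higher number a weaker inhibitor. Compound 1 `CCCCn1cnc2[nH]c(=O)[nH]c(=O)c21` gives 27000 nM in this assay. Compound 2 `C#CCn1c(=O)[nH]c2ncn(C)c2c1=O` gives 22000 nM in this assay, and the gap between compound 2 and compound 1 lies within the scatter of such measurements, so the two numbers cannot be told apart on this evidence. Both values sit in the weak range.

Compound 3 `Cn1cnc2[nH]c(=O)[nH]c(=O)c21` has not yet been measured in this assay. It differs from compound 2 by a single change: hydrogen in place of propargyl on an aromatic nitrogen. Among the measured compounds shown here, no measured pair shows this particular change, so the size of the step cannot be read from the data in hand. For the measured compounds named here, on the shared core, the two measured compounds agree only that affinity is weak; no step on either side exceeds the scatter.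

The loss of the three-carbon chain is expected to weaken binding somewhat, so the step from compound 2 to compound 3 is estimated at a 2.7-fold higher number from compound 2 to compound 3 (0.44 log units; beyond the scatter). Compound 3 is therefore expected to give about 60000 nM in this assay, within a range from 20000 nM to 200000 nM.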

Compound 3, inhibition constant: 33000 nM
Estimate against measurement, compound 3: 1.8-fold (0.26 log units) above; measured number inside the range.
By their numbers in this assay, from the lowest: compounds 2, 1 and 3 (each within the scatter of the next).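

In this assay, hydrogen in place of propargyl on an aromatic nitrogen of the six-membered aromatic ring gives a 1.5-fold higher number from compound 2 to compound 3 (0.18 log units; within the scatter), so on these numbers propargyl and hydrogen cannot be told apart at this position. The second one-place comparison, hydrogen in place of propyl on a saturated chain carbon bound to an aromatic nitrogen, gives a 1.2-fold higher number from compound 1 to compound 3 (0.09 log units; within the scatter), so the two groups at that place cannot be told apart either, and in both comparisons the numbers stay in the weak range. Nothing further is available that bears on these results.

The compounds shown leave open whether a longer chain, a benzyl group or a chain ending in an amine or a carboxylic acid on either aromatic nitrogen would give a number beyond the scatter of compound 3. Also open is whether propargyl on the one nitrogen, together with a saturated chain on the other, would give a number that can be told apart from those of the compounds shown.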